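Anilinopyrimidine series: replacing the difluorophenyl arm

The compounds below may be only part of what the source reports. "The series", "measured", "known", "first", "only" and "open" are said of these compounds alone.

Measured so far:
- compound 1, `C=CC(=O)Nc1cc(Nc2ncc(Cl)c(Nc3ccccc3S(=O)(=O)C(C)C)n2)c(OC(C)C)cc1N1CCN(CC)CC1`: < 0.3 nM
- compound 2, `C=CC(=O)Nc1cc(Nc2ncc(Cl)c(Nc3c(F)cccc3F)n2)c(OC)cc1N1CCN(C)CC1`: 2900 nM

For the measured compounds named here, in a functional assay on NCI-H3122 cells (Homo sapiens) for inhibition, read by CellTiter-Glo, with a stated time of 72 h (a higher number here means a weaker inhibitor of growth, a lower number a stronger inhibitor of growth), compound 2 gives 2900 nM, the only plain number so far. Compound 1 sits at the limit of < 0.3 nM in this assay, at which 1 of the 2 values shown sits, a limit and not a number. Compound 3, `C=CC(=O)Nc1cc(Nc2ncc(Cl)c(Nc3ccccc3S(=O)(=O)N(C)C)n2)c(OC)cc1N1CCN(C)CC1`, is not yet measured; it differs from compound 2 by 2-(dimethylsulfamoyl)phenyl in place of 2,6-difluorophenyl on a nitrogen on an aromatic ring. Going by the values given here, no step between measured compounds is available, so the size of the change cannot be read from the data directly. Compound 1 carries a sulfonyl-bearing phenyl on the same nitrogen and reaches the limit, so the move away from 2,6-difluorophenyl is expected to strengthen growth inhibition markedly. Compound 3 is expected at 5 nM, with a range of 1 nM to 30 nM. This estimate means a downward step a 580-fold lower number from compound 2 to compound 3 (2.76 log units; beyond the scatter), expected to lie well beyond the scatter.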

Compound 3, concentration for 50% growth inhibition: 11 nM
Estimate against measurement, compound 3: 2.2-fold (0.34 log units) below; low and high end bracket the measured number.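

For the compounds shown here, on the nitrogen on an aromatic ring, 2-(dimethylsulfamoyl)phenyl in place of 2,6-difluorophenyl gives a 260-fold lower number from compound 2 to compound 3 (2.42 log units; beyond the scatter) in this assay, the only step that can be read directly. This exchange of one arm, with the rest of compound 2 unchanged, is enough for a large gain in growth inhibition, so this position alone has a strong hold on the read-out. Compound 1 also carries a sulfonyl-bearing phenyl on this nitrogen, but its value is a limit and not a number: the limit of < 0.3 nM in this assay, at which 1 of the 3 values shown sits.

Going by these compounds alone, compound 1 differs from compound 3 in more than one place, so no step between them can be read. On these data alone, whether the gain depends on the sulfonyl group remains open; an unsubstituted phenyl, or a phenyl bearing a carboxamide or a nitrile, on this nitrogen would address that.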